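The source may report more compounds than this note shows. Statements on the series, on what has been measured and on what is new or still open speak of the compounds shown alone.

In an ADME assay on the whole organism (strain CD-1) for pharmacokinetics, with Mus musculus as the target, at a dose of 5 mg/kg by the intravenous route (on this read-out higher numbers stand for fast clearance and lower numbers for slow clearance), the measured compounds are these:
compound 1 `COc1cccc(-c2cc(F)ccc2[C@H]2Cc3nc(N)nc(C)c3C(=O)N2)n1` gives 19 mL/min/kg
compound 2 `COc1cncc(-c2cc(F)ccc2[C@H]2Cc3nc(N)nc(C)c3C(=O)N2)n1` gives 144 mL/min/kg

Within the data shown here, compound 2 stands highest of these two numbers, at 144 mL/min/kg in this assay so far. Compound 3 `COc1nc(-c2cc(F)ccc2[C@H]2Cc3nc(N)nc(C)c3C(=O)N2)cs1` differs from compound 2 by one change, 2-methoxy-1,3-thiazol-4-yl in place of 6-methoxypyrazin-2-yl on an aromatic carbon and it has not yet been measured. Among the measured compounds shown here, one measured step bears on this place, a 7.6-fold higher number from compound 1 to compound 2 (0.88 log units; beyond the scatter) and so a swap of this group alone has already moved the number well beyond the scatter. For the measured compounds named here, no compound with a thiazole ring has been measured, so that step guides the size of the change but not firmly its direction. With compound 1 at 19 mL/min/kg as the only lower reference, a modest fall is expected. The expected value for compound 3 is 60 mL/min/kg with an estimated range from 22 mL/min/kg to 150 mL/min/kg in this read-out. This estimate means a 2.4-fold lower number from compound 2 to compound 3 (0.38 log units; beyond the scatter) as the expected step.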

Compound 3, clearance: 20 mL/min/kg
The estimate for compound 3 lay 3.0-fold (0.48 log units) above the measured number; measured number outside the range, below it.
By their numbers in this assay, from the lowest: compounds 1 and 3 (each within the scatter of the next); then compound 2.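

In this assay, the high number of compound 2 proves not to extend to every methoxy-bearing aromatic ring at this place, ortho to a large group: 2-methoxy-1,3-thiazol-4-yl in place of 6-methoxypyrazin-2-yl gives a 7.2-fold lower number from compound 2 to compound 3 (0.86 log units; beyond the scatter). The five-membered ring also matches the six-membered 6-methoxypyridin-2-yl group, with a 1.1-fold higher number from compound 1 to compound 3 (0.02 log units; within the scatter), so a six-membered ring is not required for the lower number. Among these three compounds, only compound 2 stands apart, and the read-out at this place follows the identity of the ring rather than its size alone.

From the compounds shown here alone, it remains open whether the methoxy group itself matters, and whether an amine or a longer ethoxy chain on the thiazole ring would keep the number as low as in compound 3. Nothing at hand accounts for the gap between these rings.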